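Methyl for fluoro on the aryl ring of the shared core

A few compounds are considered here, and "the series" means these few. Any claim that something is new, unique, unknown or untested is made for them only; others in the source may bear on it.

Of the compounds shown here, three sharing one core have been measured in a functional assay, read by spectrophotometry, with a stated time of 15 min, tested at 40 ug/mL; a higher number here means a stronger effect of the compound at the concentration tested, a lower number a weaker effect. Compound 1 `COC(=O)c1cc(-c2csc(N/N=C/c3cccs3)n2)ccc1OCc1ccccc1` gives 82.8%. Compound 2 `Clc1ccc(-c2csc(N/N=C/c3cccs3)n2)cc1` gives 83.2%. Compound 3 `Fc1ccc(-c2csc(N/N=C/c3cccs3)n2)cc1` gives 87.5%. On these numbers compound 3 holds the highest value, yet its separation from compound 2 and from compound 1 stays within the scatter, so the three read as one band rather than an order.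

The next member is compound 4 `Cc1ccc(-c2csc(N/N=C/c3cccs3)n2)cc1`, which differs from compound 3 as follows: methyl in place of fluoro on an aromatic carbon. Going by the values given here, the one measured step that touches the same aromatic carbon is a number 4.3 percentage points higher from compound 2 to compound 3 (within the scatter), a change within the scatter. Compound 1, with other groups on that ring, also sits in the same band. Among the compounds with values here, nothing among the measured compounds points to a step beyond the scatter for methyl in place of fluoro.

The step from compound 3 to compound 4 is therefore expected to be a number 3.5 percentage points lower from compound 3 to compound 4 (within the scatter), a movement not beyond the scatter. For compound 4 the expected value in this assay is 84%, with a range from 72% to 93%.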

Compound 4, a percentage reported as inhibition, at one concentration (the size of the read-out at that concentration, not a potency): 82.8%
Beside the measured number, compound 4's estimate is 1.2 percentage points above it, within the range that was stated.
By their numbers in this assay, from the lowest: compounds 1, 4, 2 and 3 (each within the scatter of the next).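

In this assay, the aromatic carbon para to a large group has now carried fluoro, chloro and methyl, and the two new steps both stay inside the usual spread: a number 4.7 percentage points lower from compound 3 to compound 4 (within the scatter) and a number 0.4 percentage points lower from compound 2 to compound 4 (within the scatter). Going by these compounds alone, until now this position had been seen only with the two halogens, so compound 4 extends the flat picture to a carbon substituent, and methyl in place of either halogen gives no readable change at this concentration. Nothing available here bears on why these exchanges leave the read-out unmoved.

The compounds shown leave open whether any group at this carbon can move the read-out beyond the scatter, for example an amine, a carboxylic acid, a methoxy group or a longer chain such as butyl. Compound 2, compound 3 and compound 4 are also compared at a single concentration in this assay, which gives the size of the effect at that concentration only, so how their effects compare at other concentrations remains unresolved.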